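Swapping Bromo for Fluoro on the Sulfonamide Aryl Ring

The compounds below may be only part of what the source reports. "The series", "measured", "known", "first", "only" and "open" are said of these compounds alone.

Compound 1 `COc1ccc(S(=O)(=O)Nc2cccc(Br)c2)cc1N1CCNCC1` and compound 2 `COc1ccc(S(=O)(=O)Nc2cc(Br)cc(F)c2Cl)cc1N1CCNCC1` share one core and differ only in the ring carried on the sulfonamide nitrogen. In an assay on isolated protein for binding affinity to 5-hydroxytryptamine receptor 6 (Homo sapiens) (a lower number here means a stronger inhibitor, a higher number a weaker inhibitor), compound 1 gives 1.26 nM, while compound 2 gives 3.16 nM. Within the data shown here, the step of a 2.5-fold higher number from compound 1 to compound 2 (0.40 log units; beyond the scatter) was modest, and compound 2 therefore stands highest of the two numbers measured so far. Compound 3 `COc1ccc(S(=O)(=O)Nc2cc(F)cc(F)c2Cl)cc1N1CCNCC1` differs from compound 2 by a single change: fluoro in place of bromo on an aromatic carbon. Among the measured compounds shown here, no measured step swaps one halogen for another on this ring; the only step known concerns a broader change of substituents and was modest, so a small step in this assay is expected here, probably within the scatter and without a clear direction. The estimate for compound 3 in this assay is 3.5 nM, with a range from 1.2 nM to 10 nM. For compound 3 this means an expected step of a 1.1-fold higher number from compound 2 to compound 3 (0.04 log units; within the scatter).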

Compound 3, inhibition constant: 31.6 nM
Compound 3: middle estimate off by 9.0-fold (0.96 log units), on the low side, outside the stated range (above it).
By their numbers in this assay, from the lowest: compound 1; then compound 2; then compound 3.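

In this assay, the position para to a chloro group and meta to a fluoro group proves sensitive to which halogen it carries: exchanging bromo for fluoro gives a 10-fold higher number from compound 2 to compound 3 (1.00 log units; beyond the scatter), a change of a single atom. That exchange moves the number further than the broader ring change did, which gave a 2.5-fold higher number from compound 1 to compound 2 (0.40 log units; beyond the scatter). The two changes together amount to a 25-fold higher number from compound 1 to compound 3 (1.40 log units; beyond the scatter), and of the three compounds, only compound 3 has lost its bromo group. Nothing measured here accounts for this sensitivity.

As far as these compounds go, whether a methyl group or a nitrile at this position would keep the number close to that of compound 2 remains open. Also open is what the chloro group and the neighbouring fluoro group each contribute on their own, as no pair shown changes only one of them.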